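Swapping ethylcarbamoyl for bromo in a cytotoxicity test

The source may hold more compounds than are shown below. What is called first, only, known or untested is meant among the compounds shown, and "the series" means these compounds.

Compound 1 `CCCCc1cc2c(=O)c(C(C)=O)c[nH]c2cc1OCCOc1ccccc1`: "not determined" (no result reported)
Compound 2 `CCCCc1cc2c(=O)c(C(=O)NCC)c[nH]c2cc1OCCOc1ccccc1`: > 20000 nM

In an ADME assay on J774 cells (Mus musculus) for cytotoxicity (on this read-out higher numbers stand for an effect only at larger amounts of compound and lower numbers for an effect already at smaller amounts), compound 2 gives > 20000 nM, which is a limit of the assay and not a number. Compound 3 `CCCCc1cc2c(=O)c(Br)c[nH]c2cc1OCCOc1ccccc1` shares its core but has bromo in place of ethylcarbamoyl on an aromatic carbon. For the measured compounds named here, no measured pair shows the size of such a change. A small move towards lower numbers in this assay is expected, perhaps little beyond the usual scatter, and the estimated step is an at least 1.3-fold lower number from compound 2 to compound 3 (0.12 log units; that floor lies within the scatter). The estimate for compound 3 is 15000 nM, with an expected range of 5000 nM to 30000 nM.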

Compound 3, half-maximal effective concentration: 8070 nM
The estimate for compound 3 lay 1.9-fold (0.27 log units) above the measured number; the measured number falls inside the stated range.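

In this assay, bromo in place of ethylcarbamoyl on this aromatic carbon gives an at least 2.4-fold lower number from compound 2 to compound 3 (0.39 log units; beyond the scatter). Compound 2 alone could not show that a change at this position can move the number beyond the scatter. The step has only a lower bound because compound 2 stands at a limit, not a number: the limit of > 20000 nM in this assay, at which 1 of the 3 values shown sits.

As far as these compounds go, it remains open whether the shift comes from the loss of ethylcarbamoyl or from the presence of bromo. Chloro, an amine or a carboxylic acid on the same carbon would help separate the two.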